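Removing a Fluorine from a Series Without Measurable Cytotoxicity

A few compounds are considered here, and "the series" means these few. Any claim that something is new, unique, unknown or untested is made for them only; others in the source may bear on it.

Compound 1 `Cc1cc(-c2ccc(C#N)c(F)c2)ccc1Oc1ccnc(Nc2ccc(C#N)cc2)n1` was tested in a functional assay on MT4 cells (Homo sapiens) for cytotoxicity, read by MTT assay, with a stated time of 5 days (on this read-out lower numbers stand for higher toxicity in this test and higher numbers for lower toxicity in this test), where compound 1 reached only the limit of the assay, > 296000 nM, and not a number. Compound 2 `N#Cc1ccc(Nc2nccc(Oc3ccc(-c4ccc(C#N)c(F)c4)cc3F)n2)cc1` likewise gave only the limit > 294000 nM. Compound 3 `N#Cc1ccc(Nc2nccc(Oc3c(F)cc(-c4ccc(C#N)cc4)cc3F)n2)cc1` also stopped at the limit > 294000 nM. Going by the values given here, the single step between measured pairs, a step that the two limits leave unreadable from compound 1 to compound 2, yields no size; both of its ends are limits. Compound 4 `Cc1cc(-c2ccc(C#N)cc2)ccc1Oc1ccnc(Nc2ccc(C#N)cc2)n1` differs from compound 1 by hydrogen in place of fluoro on an aromatic carbon. With every value of the series resting on a limit, the step to compound 4 in this assay cannot be sized from the data, and another value at the limit is expected. Compound 4 is estimated at 300000 nM, with a range from 100000 nM to 1000000 nM. The expected step is a step that the limit leaves unreadable from compound 1 to compound 4.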

Compound 4, half-maximal cytotoxic concentration: > 310000 nM
Compound 4 was reported as a limit (the forecaster's own chance of this, stated with the estimate: 85%); at least 1.0-fold (0.01 log units) between middle value and limit.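

Compound 1 and compound 4 both stopped at limits, so the step between them cannot be read. The compounds shown leave open at what concentration, if any, each would become toxic in this assay.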